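The source may hold more compounds than are shown below. What is called first, only, known or untested is meant among the compounds shown, and "the series" means these compounds.

Measured so far in a functional assay on HepG2 cells (Homo sapiens) for antiproliferative activity, read by MTT assay, with a stated time of 72 h; on this read-out lower numbers stand for stronger inhibition and higher numbers for weaker inhibition:
compound 1 `Cc1nn(C)c(Oc2ccc(F)cc2)c1/C=N\CCCCCOc1cc2oc(=O)cc(C)c2cc1Cl` — > 25000 nM
compound 2 `Cc1nn(C)c(Oc2ccc(I)cc2)c1/C=N\CCCCCOc1cc2oc(=O)cc(C)c2cc1Cl` — > 25000 nM
compound 3 `Cc1nn(C)c(Oc2cccc(Cl)c2)c1/C=N\CCCCCCOc1cc2oc(=O)cc(C)c2cc1Cl` — 6220 nM

The values of compound 1 and compound 2 are each a limit of this assay, not a number; the step that the two limits leave unreadable from compound 1 to compound 2 is therefore unreadable. Within the data shown here, compound 3 stands as the only compound of the three with a number in this assay, the other two sitting at the limit of > 25000 nM in this assay, at which 2 of the 3 values shown sit.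

Compound 4 `Cc1nn(C)c(Oc2ccc(OC(F)(F)F)cc2)c1/C=N\CCCCCCOc1cc2oc(=O)cc(C)c2cc1Cl` is not yet measured. It differs from compound 3 by 4-(trifluoromethoxy)phenyl in place of 3-chlorophenyl on an oxygen on an aromatic ring. Among the measured compounds shown here, no measured step bears directly on this change: the only step between compounds differing in one place is unreadable, and compound 3 has no neighbour that differs from it only in this group. The expectation for compound 4 therefore rests on compound 3 alone, with wide uncertainty, and a change of no clear direction is expected, a 1.6-fold higher number from compound 3 to compound 4 (0.21 log units; within the scatter). Compound 4 is estimated at 10000 nM, in the range 3000 nM to 30000 nM; a limit rather than a number is a real possibility.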

Compound 4, half-maximal inhibitory concentration: 8160 nM
Compound 4: the middle estimate sits 1.2-fold (0.09 log units) above what was measured; the range from low to high includes it.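

In this assay the position on an oxygen on an aromatic ring gets its first readable step, with a 1.3-fold higher number from compound 3 to compound 4 (0.12 log units; within the scatter) for 4-(trifluoromethoxy)phenyl in place of 3-chlorophenyl. The exchange replaces a group of 7 heavy atoms and 0 hydrogen-bond acceptors with one of 11 heavy atoms and 1 hydrogen-bond acceptor, yet this pair of groups cannot be told apart in this read-out. Among these compounds, the earlier step, iodo in place of fluoro, cannot be read, so this pair is the only sized comparison of the aromatic group so far.

Going by these compounds, whether a phenoxy ring carrying an amine or a carboxylic acid would read the same remains open. The two compounds at a limit give no number to set against compound 3 or compound 4: the limit of > 25000 nM in this assay, at which 2 of the 4 values shown sit.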